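The source may hold more compounds than are shown below. What is called first, only, known or untested is meant among the compounds shown, and "the series" means these compounds.

Compound 1 `COc1ccc(N(CC(=O)NCCCSc2ccccc2)C(=O)CCSC2=C(C)C(=O)c3ccccc3C2=O)cc1` and compound 2 `COc1ccc(N(CC(=O)NCCC[Te]c2ccccc2)C(=O)CCSC2=C(C)C(=O)c3ccccc3C2=O)cc1` share one core and differ at a single point: a group of 7 heavy atoms (6 carbon, 1 tellurium; one six-membered aromatic ring of carbon only) in place of a group of 7 heavy atoms (6 carbon, 1 sulfur; one six-membered aromatic ring of carbon only), on a saturated chain carbon, three bonds along the chain from an amide-type nitrogen. In an ADME assay on cells (Fibroblast, Homo sapiens) for cytotoxicity, read by MTT assay, with a stated time of 24 h (on this read-out higher numbers stand for weaker inhibition and lower numbers for stronger inhibition), compound 1 gives 26000 nM, and in this assay compound 2 gives 4000 nM, a step of a 6.5-fold lower number from compound 1 to compound 2 (0.81 log units; beyond the scatter). Compound 3 `COc1ccc(N(CC(=O)NCCCSc2ccccc2)C(=O)c2ccccc2)cc1` carries a different core; how the cores of compound 1 and compound 3 differ is not broken down here. In this assay compound 3 reaches only the limit of the assay, >= 100000 nM, so for compound 3 no number is known, as the limit of >= 100000 nM in this assay, at which 1 of the 3 values shown sits, shows. Compound 4 `COc1ccc(N(CC(=O)NCCC[Te]c2ccccc2)C(=O)c2ccccc2)cc1` is made from compound 3 by the same change that turns compound 1 into compound 2: a group of 7 heavy atoms (6 carbon, 1 tellurium; one six-membered aromatic ring of carbon only) in place of a group of 7 heavy atoms (6 carbon, 1 sulfur; one six-membered aromatic ring of carbon only), on a saturated chain carbon, three bonds along the chain from an amide-type nitrogen. Since compound 3 sits at the limit, the step to compound 4 in this assay cannot be read from a number; still, by the size seen in a 6.5-fold lower number from compound 1 to compound 2 (0.81 log units; beyond the scatter), compound 4 is expected to give a lower number than compound 3 by about an at least 3.3-fold lower number from compound 3 to compound 4 (0.52 log units; beyond the scatter). Compound 4 is therefore estimated at 30000 nM, with a range from 8000 nM to 100000 nM, and a fair chance that only a limit is reported.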

Compound 4, half-maximal inhibitory concentration: 7500 nM
Estimate against measurement, compound 4: 4.0-fold (0.60 log units) above; the whole stated range lies above it.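

In this assay, placing the tellurium group where phenylsulfanyl stood gives an at least 13-fold lower number from compound 3 to compound 4 (1.12 log units; beyond the scatter), so the step keeps its direction on the second of the two cores shown, though two cores are too few to establish a rule for the series. Whether its size also carries over remains unsettled, and the two steps cannot be ranked against each other: the same change on two cores in this assay, a 6.5-fold lower number (0.81 log units; beyond the scatter) from compound 1 to compound 2 and an at least 13-fold lower number (1.12 log units; beyond the scatter) from compound 3 to compound 4; the limit leaves it open whether they differ The value for compound 3 is a limit and not a number, so the true size of the new step is unknown: the limit of >= 100000 nM in this assay, at which 1 of the 4 values shown sits.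

The compounds shown cover only the exchange of sulfur for tellurium on these two cores, so it remains open where a phenylselanyl group would fall relative to the sulfur and tellurium groups. As far as these compounds go, it is also open whether the step would persist with a longer chain joining the tellurium group to the amide-type nitrogen, or on a core bearing an amine or a carboxylic acid.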